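The compounds below may be only part of what the source reports. "The series", "measured", "known", "first", "only" and "open" are said of these compounds alone.

Working notes on a series of four compounds. Compound 1 `O=C1CC(c2ccccc2)n2ncnc2N1` and compound 2 `O=C1CC(c2ccccc2F)n2ncnc2N1` share one core; compound 3 `O=C1CC(c2ccccc2)n2ccnc2N1` and compound 4 `O=C1CC(c2ccccc2F)n2ccnc2N1` share another. The difference between the two cores is not broken down here.

In a functional assay on the whole organism (strain Kunming) with Mus musculus as the target (on this read-out higher numbers stand for an effect only at larger amounts of compound and lower numbers for an effect already at smaller amounts), compound 1 gives 51.9 mg/kg and compound 2 gives 31.7 mg/kg. The change between them is fluoro in place of hydrogen on an aromatic carbon and the resulting step is a 1.6-fold lower number from compound 1 to compound 2 (0.21 log units; within the scatter). In this assay compound 3 gives 68.2 mg/kg; set against compound 1 this lies within the scatter, set against compound 2 it lies beyond it, so compound 3 and compound 1 cannot be ordered, while compound 3 stands apart from compound 2.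

Compound 4 has not yet been measured in this assay. It differs from compound 3 by fluoro in place of hydrogen on an aromatic carbon, the same change that separates compound 2 from compound 1; across the series this change occurs twice in all, once measured and once not. Within the data shown here, a step of similar size is expected from compound 3 to compound 4, namely a 1.5-fold lower number from compound 3 to compound 4 (0.17 log units; within the scatter), because the one measured instance a 1.6-fold lower number from compound 1 to compound 2 (0.21 log units; within the scatter) stayed within the scatter and nothing points to a larger effect on the second core. The expectation rests on a single measured pair and is correspondingly uncertain. Compound 4 is therefore estimated at 46 mg/kg, with a plausible range from 27 mg/kg to 78 mg/kg.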

Compound 4, dose for half-maximal effect: 88 mg/kg
Estimate against measurement, compound 4: 1.9-fold (0.28 log units) below; the measured number lies above the stated range.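

In this assay, fluoro in place of hydrogen on an aromatic carbon of the core of compound 3 gives a 1.3-fold higher number from compound 3 to compound 4 (0.11 log units; within the scatter), and compound 3 and compound 4 cannot be ordered. The two instances of the change are printed with opposite signs, yet each stays within the scatter and so does the gap between them: the same change on two cores in this assay, a 1.6-fold lower number (0.21 log units; within the scatter) from compound 1 to compound 2 and a 1.3-fold higher number (0.11 log units; within the scatter) from compound 3 to compound 4, 2.1-fold (0.32 log units) apart, within the scatter of two such steps. This shows no measurable difference between the two cores in how the change reads out, but it does not show that the change transfers as a real effect, and with neither step separating its pair, two pairs cannot settle whether the outcome depends on the core.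

The compounds shown leave open whether chloro, methoxy or trifluoromethyl in place of that fluoro would give a step beyond the scatter on either core. Also open, going by these compounds, is whether an amine or a carboxylic acid on the same aromatic ring, or a methyl group in place of the amide hydrogen, would move the number in this whole-organism read-out on both cores alike.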